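Cyclohexane-1,3-diamine bis-amides: swapping an aryl amide for picolinamide

A few compounds are considered here, and "the series" means these few. Any claim that something is new, unique, unknown or untested is made for them only; others in the source may bear on it.

Measured so far:
compound 1 `CN(C)c1cccc(C(=O)N[C@H]2CCC[C@H](NC(=O)c3cccc(Cl)c3)C2)c1`: > 10000 nM
compound 2 `O=C(N[C@H]1CCC[C@H](NC(=O)c2ccccn2)C1)c1ccccn1`: 1150 nM

In a functional assay on HEK293 cells for antagonist activity at metabotropic glutamate receptor 5 (Homo sapiens), read by FLIPR and calcium flux (on this read-out lower numbers stand for stronger inhibition and higher numbers for weaker inhibition), compound 1 reaches only the limit of the assay, > 10000 nM, and no number is known for it; this is the case (the limit of > 10000 nM in this assay, at which 1 of the 2 values shown sits). Compound 2, carrying pyridin-2-yl amides on both sides of the shared core, gives 1150 nM in this assay.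

Compound 3 `Cc1cccc(C(=O)N[C@H]2CCC[C@H](NC(=O)c3cccc(Cl)c3)C2)n1` is the next target. It differs from compound 1 by 6-methylpyridin-2-yl in place of 3-(dimethylamino)phenyl on a carbonyl carbon. Because compound 2 with its pyridin-2-yl amides gives 1150 nM, a move into the measurable range is expected for compound 3. The expected step from compound 1 to compound 3 is an at least 3.3-fold lower number from compound 1 to compound 3 (0.52 log units; beyond the scatter), towards stronger inhibition. Compound 3 is estimated at 3000 nM, with a range from 700 nM to 12000 nM, in this assay.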

Compound 3, half-maximal inhibitory concentration: 290 nM
Compound 3: the middle estimate sits 10-fold (1.01 log units) above what was measured; the measured number lies below the stated range.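

At this carbonyl carbon, with the rest of compound 1 left unchanged, 6-methylpyridin-2-yl in place of 3-(dimethylamino)phenyl brings the compound into the measurable range of this assay, giving an at least 34-fold lower number from compound 1 to compound 3 (1.53 log units; beyond the scatter). The size of this step is only a bound, since the entry for compound 1 is a limit and not a number: the limit of > 10000 nM in this assay, at which 1 of the 3 values shown sits.
Compound 3 also shows that a measured value does not need pyridin-2-yl amides on both sides of the shared core, as 6-methylpyridin-2-yl on one side is enough.

The compounds shown do not divide the step between the ring nitrogen and the methyl group. Going by these compounds, it also remains open whether an ethyl or a methoxy group in place of that methyl would hold the value of compound 3 at 290 nM.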